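Shortening the ester chain of compound 2

The compounds below may be only part of what the source reports. "The series", "measured", "known", "first", "only" and "open" are said of these compounds alone.

In an ADME assay on a cell-free system (plasma, Homo sapiens) for metabolic stability, read by LC-MS (on this read-out lower numbers stand for a shorter-lived compound and higher numbers for a longer-lived compound), compound 1 (`NCc1ccc(C(=O)Nc2ccncc2F)cc1-c1cccc(C(=O)Oc2ccccc2)c1`) gives 0.117 h while compound 2 (`CCCCCCOC(=O)c1cccc(-c2cc(C(=O)Nc3ccncc3)ccc2CN)c1`) gives 0.833 h as the higher of the two numbers, a gap beyond the scatter. Compound 3 (`CC(N)c1ccc(C(=O)Nc2ccncc2)cc1-c1ccc(F)cc1`) gives > 2 h and this is a limit, not a number. Compound 4 (`CCOC(=O)c1cccc(-c2cc(C(=O)Nc3ccncc3)ccc2CN)c1`) departs from compound 2 by one change (hydrogen in place of butyl on a saturated chain carbon, two bonds along the chain from an oxygen next to a carbonyl group): hydrogen in place of butyl on a saturated chain carbon, two bonds along the chain from an oxygen next to a carbonyl group, so that hexyloxy becomes ethoxy. Within the data shown here, no measured pair isolates this change, so with compound 2 at 0.833 h as the only guide, no shift beyond the scatter is expected in this assay in either direction. For compound 4 the estimate is 1 h (range 0.35 h to 2.5 h).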

Compound 4, half-life: 0.683 h
For compound 4 the middle estimate is 1.5-fold (0.17 log units) above the measured one; measured number inside the range.
By their numbers in this assay, from the lowest: compound 1; then compounds 4 and 2 (each within the scatter of the next). At a limit, above all of these: compound 3.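

In this assay, going from hexyloxy to ethoxy gives a 1.2-fold lower number from compound 2 to compound 4 (0.09 log units; within the scatter). Among these compounds, this is the first pair that differs in one place, and it shows that removing butyl from this saturated chain carbon does not separate the two esters on this read-out. Nothing measured here bears on why the two lie so close.

Still open, on these data alone, is whether a methoxy ester, a chain longer than hexyl or a carboxylic acid at this position would also stay within the scatter of compound 4. As far as these compounds go, it is also open whether an amide in place of the ester would do so.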